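Adding a Second Chloro Group: Does the Gain Carry Over?

The source may hold more compounds than are shown below. What is called first, only, known or untested is meant among the compounds shown, and "the series" means these compounds.

Compound 1 `ClCc1cccc(Cn2cnc3ncnc(Cl)c32)c1` and compound 2 `ClCc1ccccc1Cn1cnc2ncnc(Cl)c21` are built from the same atoms joined differently; the difference between their two cores is not broken down here. In a functional assay on NCI-H226 cells (Homo sapiens) for cytotoxicity, read by sulforhodamine B assay, with a stated time of 48 h (a lower number here means a stronger inhibitor of growth, a higher number a weaker inhibitor of growth), compound 1 gives 3160 nM, and compound 2 gives 3380 nM, two numbers that lie within the usual scatter of each other. Compound 3 `ClCc1cccc(Cn2cnc3nc(Cl)nc(Cl)c32)c1` arises from compound 1 by a single change, (chloro in place of hydrogen on an aromatic carbon), and in this assay compound 3 gives 1280 nM. That step is a 2.5-fold lower number from compound 1 to compound 3 (0.39 log units; beyond the scatter). Compound 4 `ClCc1ccccc1Cn1cnc2nc(Cl)nc(Cl)c21` has not yet been measured. It arises from compound 2 by the same change, (chloro in place of hydrogen on an aromatic carbon), at a place described in exactly the same words as for compound 3. Because a 2.5-fold lower number from compound 1 to compound 3 (0.39 log units; beyond the scatter) was a modest lowering of the number, the step from compound 2 to compound 4 is expected to be of similar size, a 2.5-fold lower number from compound 2 to compound 4 (0.40 log units; beyond the scatter). This rests on one measured pair only, so the expectation is tentative. For compound 4 in this assay the estimate is 1350 nM, with a likely range from 700 nM to 2700 nM.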

Compound 4, concentration for 50% growth inhibition: 2130 nM
Estimate against measurement, compound 4: 1.6-fold (0.20 log units) below; the measured number falls inside the stated range.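

On the core of compound 2, chloro in place of hydrogen on the aromatic carbon between two ring nitrogen atoms gives a 1.6-fold lower number from compound 2 to compound 4 (0.20 log units; within the scatter), so this step alone cannot be told apart from the noise of repeated measurements. Set beside the earlier step, it offers no sign that the two cores respond differently, although only the step on the core of compound 1 stands clear of that noise: the same change on two cores in this assay, a 2.5-fold lower number (0.39 log units; beyond the scatter) from compound 1 to compound 3 and a 1.6-fold lower number (0.20 log units; within the scatter) from compound 2 to compound 4, 1.6-fold (0.19 log units) apart, within the scatter of two such steps. Two pairs therefore fit a change that carries over with a similar size, but they do not establish this as a rule for the series, and they do not show why the change acts as it does.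

The compounds shown leave open whether an amine or a methoxy group on that same carbon would shift the number as chloro does. They also leave open whether the step would hold if the chloromethyl group gave way to a longer chain.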